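Adding a Trihydroxy-Oxocyclohexenyl Ester to a Phenolic Glycoside

The compounds below may be only part of what the source reports. "The series", "measured", "known", "first", "only" and "open" are said of these compounds alone.

Compound 2, with the structure `O=C(OC[C@H]1O[C@@H](Oc2ccc(O)cc2CO)[C@H](O)[C@@H](O)[C@@H]1O)c1ccccc1`, was tested in an ADME assay on Vero cells (Chlorocebus sabaeus) for cytotoxicity, read by MTT assay, with a stated time of 72 h (on this read-out lower numbers stand for higher toxicity in this test and higher numbers for lower toxicity in this test), where compound 2 gives 137000 nM. Among the compounds with values here, of the two numbers measured so far this is the higher, yet its only neighbour, compound 1 with the structure `O=C(O[C@H]1[C@H](Oc2ccc(O)cc2COC(=O)[C@@]2(O)[C@H](O)C=CC(=O)[C@@H]2O)O[C@H](CO)[C@@H](O)[C@@H]1O)c1ccccc1`, lies within the usual scatter of it, since compound 1 gives 77300 nM in this assay. The two compounds therefore read as alike on this test.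

Compound 3, with the structure `O=C(OC[C@H]1O[C@@H](Oc2ccc(O)cc2COC(=O)[C@@]2(O)[C@H](O)C=CC(=O)[C@@H]2O)[C@H](O)[C@@H](O)[C@@H]1O)c1ccccc1`, has not yet been measured. It differs from compound 2 in one place: (1,2,6-trihydroxy-5-oxocyclohex-3-en-1-yl)carbonyl in place of hydrogen on an oxygen on a saturated carbon. Compound 1 already carries this same group, on a differently arranged sugar, and its number sits close to that of compound 2. The expected step in this assay from compound 2 to compound 3 is therefore small, a 1.6-fold lower number from compound 2 to compound 3 (0.21 log units; within the scatter), and not clearly beyond the scatter. Compound 3 is estimated at 85000 nM, within a range of 40000 nM to 170000 nM.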

Compound 3, half-maximal cytotoxic concentration: 119000 nM
The estimate for compound 3 lay 1.4-fold (0.15 log units) below the measured number, and the stated range covers the measured number.
By their numbers in this assay, from the lowest: compounds 1, 3 and 2 (each within the scatter of the next).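

Within the data shown here, the step from compound 2 to compound 3 gives the first direct look at this position, an oxygen on a saturated carbon. In this assay, putting (1,2,6-trihydroxy-5-oxocyclohex-3-en-1-yl)carbonyl in place of hydrogen there gives a 1.2-fold lower number from compound 2 to compound 3 (0.06 log units; within the scatter), so even a group of 12 heavy atoms with its own six-membered ring leaves the two compounds reading as alike on this test. Nothing available explains this likeness.

The compounds shown leave open whether a small acetyl group on the same oxygen, or a group of a different kind such as an amine or a carboxylic acid, would also read alike. They also leave open which part of the added group, if any, matters for this read-out.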